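A few compounds are considered here, and "the series" means these few. Any claim that something is new, unique, unknown or untested is made for them only; others in the source may bear on it.

Compound 3 `COc1ccc(NC(=O)CSC(=S)N[C@H]2CCOC2=O)cc1` is one of three compounds that share a core and differ only in the group on the aromatic ring. In a functional assay on EC9706 cells (Homo sapiens) for cytotoxicity, read by MTT assay, with a stated time of 72 h (on this read-out lower numbers stand for stronger inhibition and higher numbers for weaker inhibition), compound 3 gives > 128000 nM, which is a limit of the assay and not a number. Compound 1 `O=C(CSC(=S)N[C@H]1CCOC1=O)Nc1ccc(Cl)cc1` gives > 128000 nM, also a limit. Compound 2 `O=C(CSC(=S)N[C@H]1CCOC1=O)Nc1ccccc1` gives > 128000 nM, likewise a limit. Because of the limit of > 128000 nM in this assay, at which 3 of the 3 values shown sit, the steps a step that the two limits leave unreadable from compound 1 to compound 2, a step that the two limits leave unreadable from compound 1 to compound 3 and a step that the two limits leave unreadable from compound 2 to compound 3 yield no size. Compound 4 `O=C(CSC(=S)N[C@H]1CCOC1=O)Nc1ccc(F)cc1` differs from compound 3 by fluoro in place of methoxy on an aromatic carbon. The steps among the three measured compounds bear on this change but set no scale for it. For compound 4 the step that the limit leaves unreadable from compound 3 to compound 4 is expected to leave it at the limit. Compound 4 is therefore estimated at 200000 nM, with a range from 60000 nM to 600000 nM.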

Compound 4, half-maximal inhibitory concentration: 67100 nM
Compound 4: middle estimate off by 3.0-fold (0.47 log units), on the high side; the range from low to high includes it.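

In this assay compound 4, with fluoro on the aromatic carbon, is the only one of the four to give a number and not a limit, so a change at this position can yield a readable value. The steps to it are an at least 1.9-fold lower number from compound 3 to compound 4 (0.28 log units; that floor lies within the scatter), an at least 1.9-fold lower number from compound 2 to compound 4 (0.28 log units; that floor lies within the scatter) and an at least 1.9-fold lower number from compound 1 to compound 4 (0.28 log units; that floor lies within the scatter). They are floors only, because of where the other values sit: the limit of > 128000 nM in this assay, at which 3 of the 4 values shown sit.

The steps among compound 1, compound 2 and compound 3 still cannot be read. On these data alone, whether an amine or a carboxylic acid at this position would give a lower number remains open.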